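The source may hold more compounds than are shown below. What is called first, only, known or untested is meant among the compounds shown, and "the series" means these compounds.

Compounds measured:
compound 1, `CC(=O)Nc1c(C(O)(C(F)(F)F)C(F)(F)F)ccc2ccccc12`, 87%
compound 2, `CC(C)=CC(=O)Nc1c(C(O)(C(F)(F)F)C(F)(F)F)ccc2ccccc12`, 96%

In a functional assay (Sus scrofa) with sulfonylurea receptors; K-ATP channels (Homo sapiens) as the target (on this read-out higher numbers stand for larger maximal responses and lower numbers for smaller maximal responses), compound 2 stands highest of the two numbers, with compound 1 nearest, and the step of a number 9 percentage points higher from compound 1 to compound 2 (within the scatter) lies within the scatter. Compound 3, `C/C=C/C(=O)Nc1c(C(O)(C(F)(F)F)C(F)(F)F)ccc2ccccc12`, carries prop-1-en-1-yl in place of 2-methylprop-1-en-1-yl on a carbonyl carbon. The one step shown, a number 9 percentage points higher from compound 1 to compound 2 (within the scatter), changed the group on the carbonyl carbon and produced no movement beyond the scatter, so a similarly small shift, or none, is expected for this change. For compound 3 the expected step is a number 4 percentage points lower from compound 2 to compound 3 (within the scatter), giving an estimate of 92% in this assay, with a range from 78% to 104%.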

Compound 3, largest response reached (reported as efficacy), in percent of the reference or control that the assay uses: 96%
Beside the measured number, compound 3's estimate is 4 percentage points below it; the measured number falls inside the stated range.
By their numbers in this assay, from the lowest: compounds 1, 2 and 3 (each within the scatter of the next).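

In this assay, swapping 2-methylprop-1-en-1-yl for prop-1-en-1-yl on the carbonyl carbon leaves the maximal response in place (no change at the digits printed from compound 2 to compound 3 (within the scatter)), and prop-1-en-1-yl also stays within the scatter of methyl (a number 9 percentage points higher from compound 1 to compound 3 (within the scatter)). All three groups therefore give responses that this read-out cannot separate, whether or not the group holds a double bond. No measurement shown here accounts for this.

Still open, on these data alone, is whether an amine, a carboxylic acid or a longer chain on this carbonyl carbon would move the response beyond the scatter.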